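This account rests on a few compounds, and the source may have more. Where it says the series, first, only, none or still open, it means among the compounds named here.

Measured so far:
compound 1, `O=C(CC(=O)c1ccccc1OCc1ccccc1)c1nnn[nH]1`: in an ADME assay on Huh-7 cells (Homo sapiens) for cytotoxicity (a higher number here means that more compound is tolerated, a lower number that less compound is tolerated), compound 1 gives > 500000 nM
compound 2, `O=C(CC(=O)c1nnc[nH]1)c1ccc(OCc2ccc(F)cc2)cc1`: in this assay compound 2 gives > 500000 nM

Both readings are limits of the assay and not numbers. For compound 1 the reading in this assay is a limit only. For compound 2 the reading in this assay is likewise a limit only. Both sit at the limit of > 500000 nM in this assay, at which 2 of the 2 values shown sit, so no ordering between compound 1 and compound 2 can be drawn; all that is known is that neither gave a numerical value within the tested window.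

Compound 3, `O=C(CC(=O)c1nnc[nH]1)c1ccc(OCc2ccc(Cl)cc2)cc1`, is still to be measured in this assay. It differs from compound 2 by chloro in place of fluoro on an aromatic carbon, the 4-fluorobenzyl becoming a 4-chlorobenzyl. Within the data shown here, no measured pair shows this exchange, so no step size is on record for it. The step from compound 2 to compound 3 is expected to be a number no higher from compound 2 to compound 3 (the limit leaves the size open), that is, none beyond the scatter. Compound 3 is therefore expected at 500000 nM, with a range from 300000 nM to 1000000 nM, and most probably it will again be reported only as a limit.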

Compound 3, half-maximal cytotoxic concentration: > 500000 nM
Compound 3 was reported as a limit (the forecaster's own chance of this, stated with the estimate: 85%); the middle value lies on the limit itself.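

In this assay compound 2 and compound 3 both stand at a limit and not at a number, so no step can be read for the change from 4-fluorobenzyl to 4-chlorobenzyl: the limit of > 500000 nM in this assay, at which 3 of the 3 values shown sit.

The compounds shown leave open where any of the three would give a numerical value in this assay and how large a step chloro in place of fluoro would be.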